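The source may hold more compounds than are shown below. What is called first, only, known or untested is meant among the compounds shown, and "the series" means these compounds.

Measured so far in an ADME assay on HepG2 2.2.15 cells (Homo sapiens) for cytotoxicity, read by CCK-8 assay, with a stated time of 8 days; on this read-out higher numbers stand for lower toxicity in this test and lower numbers for higher toxicity in this test
compound 1 `COc1ccc(-c2cc(NC(=O)c3cccc(OC)c3O)c[nH]c2=O)cc1` gives 49200 nM
compound 2 `COc1ccc(-c2cc(NC(=O)c3ccc(C)cc3O)c[nH]c2=O)cc1` gives 46100 nM

Among the measured compounds shown here, compound 2 lies within the scatter of compound 1, the only other compound measured, so neither stands apart on these numbers. Next comes compound 3 `Cc1cccc(-c2cc(NC(=O)c3ccc(C)cc3O)c[nH]c2=O)c1` with the change 3-methylphenyl in place of 4-methoxyphenyl on an aromatic carbon in which 3-methylphenyl replaces 4-methoxyphenyl on an aromatic carbon of a six-membered aromatic ring with 1 nitrogen. For the measured compounds named here, the one measured step, a 1.1-fold lower number from compound 1 to compound 2 (0.03 log units; within the scatter), bears on this only indirectly, since it changes the group on a carbonyl carbon. Going by the values given here, no measured step changes the group at the place now altered, so the data point in neither direction. No step beyond the scatter is expected in this assay and the estimated step is a 1.0-fold lower number from compound 2 to compound 3 (0.01 log units; within the scatter) on that basis. The expected value for compound 3 is 45000 nM within an estimated range from 20000 nM to 100000 nM for now.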

Compound 3, half-maximal cytotoxic concentration: 75000 nM
The estimate for compound 3 lay 1.7-fold (0.22 log units) below the measured number, within the range that was stated.
By their numbers in this assay, from the lowest: compounds 2, 1 and 3 (each within the scatter of the next).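

Working notes: this is the first look at the aromatic carbon on the six-membered aromatic ring with 1 nitrogen, and in this assay putting 3-methylphenyl in place of 4-methoxyphenyl gives a 1.6-fold higher number from compound 2 to compound 3 (0.21 log units; within the scatter). The step shows that this position tolerates an exchange of aryl groups that alters the substituent, its place on the phenyl ring and the count of hydrogen-bond acceptors, without separating the two compounds in this read-out. No supporting measurement accompanies this result, so it offers no account of the number.

Because substituent and placement differ together here, the compounds shown cannot separate their contributions, which 3-methoxyphenyl or 4-methylphenyl at this carbon could address. Also open, from the compounds shown here alone, is whether a more different group here, such as an aminophenyl or a carboxylic acid on the phenyl ring, would give a step beyond the scatter.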